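A few compounds are considered here, and "the series" means these few. Any claim that something is new, unique, unknown or untested is made for them only; others in the source may bear on it.

Measured so far in a functional assay on QG-56 cells (Homo sapiens) for cytotoxicity, read by MTT assay, with a stated time of 48 h; a lower number here means a stronger inhibitor, a higher number a weaker inhibitor:
- compound 1 `COc1cc(/C=C/C(=O)C2=C(/C=C/c3ccc(O)c(OC)c3)NC(=O)NC2c2ccc(C)cc2)ccc1O` gives 100000 nM
- compound 2 `COc1cc(/C=C/C(=O)C2=C(/C=C/c3ccc(O)c(OC)c3)NC(=O)NC2c2ccc(O)cc2)ccc1O` gives 50000 nM

Compound 2 has a single measured neighbour, and the two values lie within the scatter of each other, so they cannot be ranked. Within the data shown here, the only measured step is a 2.0-fold lower number from compound 1 to compound 2 (0.30 log units; within the scatter), and it too swaps one group for another on an aromatic carbon.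

Next is compound 3 `COc1cc(/C=C/C(=O)C2=C(/C=C/c3ccc(O)c(OC)c3)NC(=O)NC2c2ccc(N(C)C)cc2)ccc1O`, which carries dimethylamino in place of hydroxy on an aromatic carbon, para to a large group, with the rest of the shared core unchanged: dimethylamino in place of hydroxy on an aromatic carbon. In other words, 4-hydroxyphenyl becomes 4-(dimethylamino)phenyl.

One step within the scatter is thin evidence for a different replacement, and it gives no direction. In this assay no change beyond the scatter is expected, so the estimated result is no change at the digits printed from compound 2 to compound 3 (within the scatter). The expectation rests on compound 2 at 50000 nM, and the range is kept wide. For compound 3 the estimated value is 50000 nM, with an expected range from 15000 nM to 130000 nM.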

Compound 3, half-maximal inhibitory concentration: 12500 nM
Compound 3: the middle estimate sits 4.0-fold (0.60 log units) above what was measured, outside the stated range (below it).
By their numbers in this assay, from the lowest: compound 3; then compounds 2 and 1 (each within the scatter of the next).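

In this assay, among these compounds, the aromatic carbon para to a large group now shows that the substituent there can matter: the change from 4-hydroxyphenyl to 4-(dimethylamino)phenyl gives the first step beyond the scatter, with a 4.0-fold lower number from compound 2 to compound 3 (0.60 log units; beyond the scatter). The comparison with the methyl group points the same way, with an 8.0-fold lower number from compound 1 to compound 3 (0.90 log units; beyond the scatter), so dimethylamino stands apart from both earlier groups, while hydroxy and methyl remain unranked against each other. Compound 3 is therefore the most potent of the three in this assay, although all three numbers are read from a single cell line and the step sizes are modest. Nothing measured in hand bears on why the replacement shifts the number.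

As far as these compounds go, it remains open whether the shift follows the dimethylamino group as a whole or would also appear with a simple primary amine, a diethylamino group or a ring amine such as morpholine at the same place. Equally open, from the compounds shown here alone, is where a methoxy group or a carboxylic acid at this carbon would fall, whether with compound 3 or alongside compounds 1 and 2.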